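Replacing the thiazolyl of compound 2 with methoxycarbonyl

The source may hold more compounds than are shown below. What is called first, only, known or untested is meant among the compounds shown, and "the series" means these compounds.

Among the three compounds measured in an ADME assay on PC-3 cells (Homo sapiens) for cytotoxicity, read by WST assay, tested at 100 uM (a lower number here means less inhibition, a higher number more inhibition at the concentration tested (going by the name of the read-out)), compound 2 `O=C(Nc1ccc(Cl)cc1)C1CCCN(C(=O)c2cccc(-c3nccs3)c2)C1` stands highest, giving 32%. Compound 1 `O=C(Nc1cccc(Oc2ccccn2)c1)C1CCCN(C(=O)c2cc(C(F)(F)F)cc(C(F)(F)F)c2)C1` gives 0% in this assay, and compound 3 `O=C(Nc1cccc(Oc2ccccc2)c1)C1CCCN(C(=O)c2cccc(-c3ccco3)c2)C1` gives 0%, so compound 2 is the only one of the three that shows any inhibition beyond the scatter. Compound 4 `COC(=O)c1cccc(C(=O)N2CCCC(C(=O)Nc3ccc(Cl)cc3)C2)c1` has not yet been measured. Its structure differs from compound 2 in one place: methoxycarbonyl in place of 1,3-thiazol-2-yl on an aromatic carbon. Among the measured compounds shown here, no measured pair isolates this change, so its effect is unknown. With two of three compounds at the floor, a drop toward the floor seems the more likely outcome, although a step within the scatter cannot be excluded. The expected step of a number 17 percentage points lower from compound 2 to compound 4 (beyond the scatter) is downward. Compound 4 is estimated at 15%, within 0% to 40%.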

Compound 4, a percentage reported as inhibition, at one concentration (the size of the read-out at that concentration, not a potency): 0%
Estimate against measurement, compound 4: 15 percentage points above, and the stated range covers the measured number.
By their numbers in this assay, from the lowest: compounds 1, 3 and 4 (each within the scatter of the next); then compound 2.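

Among the compounds shown here, at this aromatic carbon, the first comparison that changes only one place gives a number 32 percentage points lower from compound 2 to compound 4 (beyond the scatter) in this assay. With the rest of compound 2 kept, the inhibition it shows therefore does not survive the exchange of 1,3-thiazol-2-yl for methoxycarbonyl. No measurement here offers an explanation for this loss.

The compounds shown leave open whether other five-membered aromatic rings with hetero atoms would keep the inhibition at this position. They also leave open what an amine or a carboxylic acid would do there.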